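This account rests on a few compounds, and the source may have more. Where it says the series, first, only, none or still open, it means among the compounds named here.

Three compounds have been measured in an ADME assay on Caco-2 cells (Homo sapiens) for permeability, in the apical to basolateral direction; on this read-out lower numbers stand for lower permeability and higher numbers for higher permeability:
compound 1 `CNCc1ccc(-c2c3ncn(CC4(O)CCN(Cc5ccc(-c6ccco6)cc5Cl)CC4)c(=O)c3nn2C)cc1`, 1.06 10^-6 cm/s;
compound 2 `Cn1nc2c(=O)n(CC3(O)CCN(Cc4ccc(-c5ccco5)cc4Cl)CC3)cnc2c1-c1ccc(CNS(C)(=O)=O)cc1`, 50 10^-6 cm/s;
compound 3 `Cn1nc2c(=O)n(CC3(O)CCN(Cc4ccc(-c5ccco5)cc4Cl)CC3)cnc2c1-c1ccc(F)cc1`, 6.84 10^-6 cm/s.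

Compound 1 gives the lowest number of the three in this assay. Compound 4 `Cn1nc2c(=O)n(CC3(O)CCN(Cc4ccc(-c5ccco5)cc4Cl)CC3)cnc2c1-c1ccc(CN)cc1` differs from it by hydrogen in place of methyl on an amine nitrogen. Two measured steps start from compound 1: a 47-fold higher number from compound 1 to compound 2 (1.67 log units; beyond the scatter) and a 6.5-fold higher number from compound 1 to compound 3 (0.81 log units; beyond the scatter). In both the amine of compound 1 is either substituted further or removed altogether; neither keeps a free amine in place, so they bear only loosely on the present change. With the amine kept and only its methyl taken away, no step beyond the scatter is expected, with at most a slight lean downward. The estimate for compound 4 is 0.8 10^-6 cm/s (0.3 10^-6 cm/s to 2.5 10^-6 cm/s), which is expected to mean a 1.3-fold lower number from compound 1 to compound 4 (0.12 log units; within the scatter).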

Compound 4, apparent permeability: 0.92 10^-6 cm/s
The estimate for compound 4 lay 1.2-fold (0.06 log units) below the measured number; the range from low to high includes it.
By their numbers in this assay, from the lowest: compounds 4 and 1 (each within the scatter of the next); then compound 3; then compound 2.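

In this assay, hydrogen in place of methyl on the amine nitrogen gives a 1.2-fold lower number from compound 1 to compound 4 (0.06 log units; within the scatter), so this change does not separate the two amines. The wide gaps remain when the free amine is lost at this position, with a 7.4-fold lower number from compound 3 to compound 4 (0.87 log units; beyond the scatter) for aminomethyl in place of fluoro and a 54-fold lower number from compound 2 to compound 4 (1.74 log units; beyond the scatter) for hydrogen in place of methylsulfonyl. No evidence is available that accounts for these steps. The compounds shown leave open whether a dimethylamino group or an acetamide in the same place would read like the amines or like compound 2.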